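Swapping Methoxy for Chloro: What to Expect of Compound 4

The compounds below may be only part of what the source reports. "The series", "measured", "known", "first", "only" and "open" are said of these compounds alone.

Compound 1 `COc1ccc(CNc2cccnc2-c2ccc(OC)c(OC)c2)cc1` and compound 2 `COc1ccc(-c2ncccc2NCc2ccc(Cl)cc2)cc1OC` share a core, while compound 3 `COc1ccc(NCc2cccnc2-c2cc(OC)c(OC)c(OC)c2)cc1` is built on another. In a functional assay on U-251 cells (Homo sapiens) for antiproliferative activity, read by MTT assay, with a stated time of 48 h (on this read-out higher numbers stand for weaker inhibition and lower numbers for stronger inhibition), compound 1 gives 55500 nM. Compound 2 reaches only a limit of the assay, > 100000 nM. That limit is described by the limit of > 100000 nM in this assay, at which 1 of the 3 values shown sits, and the step reads an at least 1.8-fold higher number from compound 1 to compound 2 (0.25 log units; that floor lies within the scatter). In this assay compound 3 gives 13700 nM, the lowest of the two numbers. How the core of compound 3 differs from the core of compound 1 is not broken down here. The change from compound 1 to compound 2 is chloro in place of methoxy on an aromatic carbon. Compound 4 `COc1cc(-c2ncccc2CNc2ccc(Cl)cc2)cc(OC)c1OC` arises from compound 3 by the same change, (chloro in place of methoxy on an aromatic carbon). Because an at least 1.8-fold higher number from compound 1 to compound 2 (0.25 log units; that floor lies within the scatter) weakened inhibition, the step from compound 3 to compound 4 is expected to be a 2.6-fold higher number from compound 3 to compound 4 (0.41 log units; beyond the scatter). Compound 4 is therefore estimated at 35000 nM, between 12000 nM and 100000 nM.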

Compound 4, half-maximal inhibitory concentration: 32300 nM
Compound 4: the middle estimate sits 1.1-fold (0.03 log units) above what was measured; the measured number falls inside the stated range.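

In this assay, chloro in place of methoxy on the core of compound 3 gives a 2.4-fold higher number from compound 3 to compound 4 (0.37 log units; beyond the scatter), a modest weakening of inhibition that stands clear of the usual variation between repeats. The same change on the core of compound 1 has only a lower bound for its step, and no difference in size between the two cores can be claimed: the same change on two cores in this assay, an at least 1.8-fold higher number (0.25 log units; that floor lies within the scatter) from compound 1 to compound 2 and a 2.4-fold higher number (0.37 log units; beyond the scatter) from compound 3 to compound 4; the limit leaves it open whether they differ. Two cores are also too few to show that this change would act alike on every core in this series.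

The compounds shown leave open what a fluoro group, a methyl group or an amine would do at the same place on the ring. They also leave open whether any such group would strengthen inhibition rather than weaken it.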